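This account rests on a few compounds, and the source may have more. Where it says the series, first, only, none or still open, it means among the compounds named here.

Measured so far: compound 1 `O=C(Nc1ccccc1Cl)Nc1nn(-c2ccccc2)c(=O)c2ccccc12`, which in an assay on CHO cells for displacement of a labelled ligand from adenosine receptor A1 (Homo sapiens), tested at 10 uM (a lower number here means less inhibition, a higher number more inhibition at the concentration tested (going by the name of the read-out)), gives 0%; compound 2 `O=C(Nc1nn(-c2ccccc2)c(=O)c2ccccc12)c1ccco1`, which in this assay gives 23%.

Within the data shown here, compound 2 stands highest of the two numbers; the only measured step in this assay is a number 23 percentage points higher from compound 1 to compound 2 (beyond the scatter), a modest rise beyond the scatter.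

Compound 3 `Cc1ccccc1NC(=O)Nc1nn(-c2ccccc2)c(=O)c2ccccc12` differs from compound 2 by (2-methylphenyl)amino in place of furan-2-yl on a carbonyl carbon. This reverses the kind of change seen in the measured step, and compound 3 is thus close in build to compound 1. The measured step bears on it directly, in the opposite direction. Compound 3 is therefore expected to drop back, about a number 18 percentage points lower from compound 2 to compound 3 (beyond the scatter), to an estimated 5%, with a range of 0% to 20%.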

Compound 3, a percentage reported as inhibition, at one concentration (the size of the read-out at that concentration, not a potency): 20%
Compound 3: the middle estimate sits 15 percentage points below what was measured; the range from low to high includes it.
By their numbers in this assay, from the lowest: compound 1; then compounds 3 and 2 (each within the scatter of the next).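

In this assay, furan-2-yl on the carbonyl carbon can give way to (2-methylphenyl)amino with a number 3 percentage points lower from compound 2 to compound 3 (within the scatter), so an arylamino group in this place does not by itself bring the read-out down. The change on the aromatic carbon does count, with a number 20 percentage points higher from compound 1 to compound 3 (beyond the scatter) for methyl in place of chloro, so the low number of compound 1 goes with the chloro and not with the arylamino carbonyl as a whole. Nothing at hand explains either result.

Still open, going by these compounds, is how methoxy or fluoro on that aromatic carbon would compare with methyl and chloro. Also open, on these data alone, is whether a plain phenylamino or a longer alkyl chain on the carbonyl carbon would hold the read-out.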